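One Methyl Group Less: From Compound 2 to Compound 4

A few compounds are considered here, and "the series" means these few. Any claim that something is new, unique, unknown or untested is made for them only; others in the source may bear on it.

Of the compounds shown here, three built on a shared core have been measured in a functional assay on MCF7 cells (Homo sapiens) for cytotoxicity, read by MTT assay, with a stated time of 72 h, tested at 30 uM; a higher number here means more inhibition of growth at the concentration tested, a lower number less inhibition of growth. Compound 1 `Cc1ccnc(/C(N)=N/NC(=S)N2CCSCC2)c1` gives 74.2%. Compound 2 `Cc1ccnc(/C(N)=N/NC(=S)N2CCCCCC2)c1` gives 75.9%, which is the highest of the three numbers, although the gap to compound 1 is within the usual scatter of such measurements, so the two cannot be placed in order. Compound 3 `N/C(=N\NC(=S)N1CCOCC1)c1ccc(F)cn1` gives 56.7%, a number below compound 2 by more than the scatter.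

The next compound, compound 4 `N/C(=N\NC(=S)N1CCCCCC1)c1ccccn1`, has not yet been measured in this assay. Compared with compound 2, the change is small: hydrogen in place of methyl on an aromatic carbon. Nothing more than one carbon atom is lost, and no donor, acceptor or charge changes.

Within the data shown here, no pair of measured compounds differs by just this kind of change, so there is no measured step to lean on. Given how small the change is, the expected step from compound 2 to compound 4 in this assay is a number 5.9 percentage points lower from compound 2 to compound 4 (within the scatter), a slight drop that is not expected to go beyond the scatter. Compound 4 is therefore estimated to give about 70%, with a range from 55% to 85%.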

Compound 4, percent growth inhibition at one concentration: 76.5%
For compound 4 the middle estimate is 6.5 percentage points below the measured one, within the range that was stated.
By their numbers in this assay, from the lowest: compound 3; then compounds 1, 2 and 4 (each within the scatter of the next).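

Replacing methyl with hydrogen on this aromatic carbon, opposite the ring nitrogen, gives a number 0.6 percentage points higher from compound 2 to compound 4 (within the scatter) in this assay, the first measured step among these compounds in which only one place changes. Compound 4 therefore shows that, in this assay and on this scaffold, the methyl group is not required to retain the level of growth inhibition seen with compound 2, even though a whole carbon atom has gone from the shared core. Nothing shown explains why the reading holds when this group is removed.

Among the compounds shown, this position carries only methyl or hydrogen, so the result says nothing about a different kind of group there, such as an amine, a methoxy group, a carboxylic acid or a longer chain, any of which might still move the number in either direction. Going by these compounds, it also remains open whether methyl and hydrogen would stay level with a different ring at the other end of the molecule, as in compound 1, or in cells other than those of this single assay.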